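This account rests on a few compounds, and the source may have more. Where it says the series, first, only, none or still open, it means among the compounds named here.

Measured so far:
Compound 1 `CN1CCN(c2nc3c(cc2[N+](=O)[O-])c(=O)c(C(=O)O)cn3C2CC2)CC1c1ccccc1` gives 139000 nM in an ADME assay on Vero cells (Chlorocebus sabaeus) for cytotoxicity, read by MTT assay, with a stated time of 72 h; on this read-out higher numbers stand for weaker inhibition and lower numbers for stronger inhibition.
Compound 2 `CC(C)(C)NC(=O)C1c2ccccc2CCN1c1nc2c(cc1[N+](=O)[O-])c(=O)c(C(=O)O)cn2C1CC1` gives 124000 nM in this assay.
Compound 3 `CN1CCN(c2nc3c(cc2[N+](=O)[O-])c(=O)c(C(=O)O)cn3-c2ccc(F)cc2)CC1c1ccccc1` gives 124000 nM in this assay.

Among the measured compounds shown here, the three numbers sit close together; none of the gaps between them is beyond the usual scatter, so no compound can be called weaker or stronger than another here. Compound 1 and compound 3 differ in a single place, (4-fluorophenyl in place of cyclopropyl on an aromatic nitrogen), and this change gave a 1.1-fold lower number from compound 1 to compound 3 (0.05 log units; within the scatter). Compound 2 differs from compound 1 in more than one place; the difference between the two cores is not broken down here. Compound 4 `CC(C)(C)NC(=O)C1c2ccccc2CCN1c1nc2c(cc1[N+](=O)[O-])c(=O)c(C(=O)O)cn2-c1ccc(F)cc1` is reached from compound 2 by 4-fluorophenyl in place of cyclopropyl on an aromatic nitrogen, the same change as from compound 1 to compound 3, at a place described in the same words. The step is therefore expected to be small, a 1.1-fold lower number from compound 2 to compound 4 (0.03 log units; within the scatter), because a 1.1-fold lower number from compound 1 to compound 3 (0.05 log units; within the scatter) was within the scatter and compound 2 starts from 124000 nM. Compound 4 is thus estimated at 115000 nM, expected between 60000 nM and 220000 nM.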

Compound 4, half-maximal inhibitory concentration: 112000 nM
Compound 4: middle estimate off by 1.0-fold (0.01 log units), on the high side, and the stated range covers the measured number.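

In this assay, among the compounds shown here, 4-fluorophenyl in place of cyclopropyl on an aromatic nitrogen gave a 1.1-fold lower number from compound 2 to compound 4 (0.04 log units; within the scatter), so on this second core too the swap produces no step that can be told from repeat-measurement noise. Set beside the earlier step, the change reads the same on both cores: the same change on two cores in this assay, a 1.1-fold lower number (0.05 log units; within the scatter) from compound 1 to compound 3 and a 1.1-fold lower number (0.04 log units; within the scatter) from compound 2 to compound 4, 1.0-fold (0.01 log units) apart, within the scatter of two such steps This shows that on these two cores the swap can be carried across without a readable shift in this cytotoxicity read-out, but since neither step stands clear of the scatter, it shows agreement between two null results, not a real effect of fixed size that travels from core to core, and it says nothing about cores beyond these two.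

The compounds shown leave open whether an ethyl chain, or a phenyl ring carrying an amine, on that same aromatic nitrogen would also leave the number unmoved. They also leave open whether the swap stays this small on a core where an amine stands in place of the nitro group.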